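This account rests on a few compounds, and the source may have more. Where it says the series, first, only, none or still open, it means among the compounds named here.

Working notes on the series, in a functional assay on HCC827 cells (Homo sapiens) for antiproliferative activity, read by MTT assay, with a stated time of 72 h; on this read-out higher numbers stand for weaker inhibition and lower numbers for stronger inhibition: compound 1 (`CN1CCN(c2ccc(Nc3ncc4nc(Sc5ccccc5)n(C5CCOCC5)c4n3)cc2)CC1`) gives 42.6 nM, compound 2 (`CC(C)n1c(Sc2ccccc2)nc2cnc(Nc3ccc(N4CCN(C)CC4)cc3)nc21`) gives 290 nM and compound 3 (`CN1CCN(c2ccc(Nc3ncc4nc(Sc5ccccc5)n(C5CC5)c4n3)cc2)CC1`) gives 305 nM. Compound 3 sits at the weak end of this set. The numbers show a 1.1-fold higher number from compound 2 to compound 3 (0.02 log units; within the scatter), within the scatter, and a 7.2-fold higher number from compound 1 to compound 3 (0.85 log units; beyond the scatter), beyond it.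

Compound 4 (`CN1CCN(c2ccc(Nc3ncc4nc(Sc5ccccc5)n([C@H]5CC[C@H](O)CC5)c4n3)cc2)CC1`) carries 4-hydroxycyclohexyl in place of cyclopropyl on an aromatic nitrogen. No 4-hydroxycyclohexyl has been measured, so the nearest guide is the oxan-4-yl of compound 1, with modest steps of a 6.8-fold higher number from compound 1 to compound 2 (0.83 log units; beyond the scatter) and the reverse of the gap above. A modest move to a lower number in this assay is therefore expected, an estimated 5.5-fold lower number from compound 3 to compound 4 (0.74 log units; beyond the scatter). The estimate for compound 4 is 55 nM, with an expected range of 15 nM to 200 nM.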

Compound 4, half-maximal inhibitory concentration: 42.6 nM
Compound 4: middle estimate off by 1.3-fold (0.11 log units), on the high side; low and high end bracket the measured number.
By their numbers in this assay, from the lowest: compounds 1 and 4 (each within the scatter of the next); then compounds 2 and 3 (each within the scatter of the next).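

In this assay, 4-hydroxycyclohexyl on the aromatic nitrogen gives a 7.2-fold lower number from compound 3 to compound 4 (0.85 log units; beyond the scatter) and a 6.8-fold lower number from compound 2 to compound 4 (0.83 log units; beyond the scatter) against the two small groups, so the lower number at this position is not confined to oxan-4-yl. Replacing oxan-4-yl with 4-hydroxycyclohexyl gives no change at the digits printed from compound 1 to compound 4 (within the scatter) and thus does not separate the two groups in this read-out.

Still open, from the compounds shown here alone, is whether an aminocyclohexyl or a carboxylic acid on a cyclohexyl ring at this nitrogen would keep the lower number, and whether the opposite arrangement of the hydroxyl would. No supporting evidence is available to explain these results.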